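The source may hold more compounds than are shown below. What is called first, only, known or untested is meant among the compounds shown, and "the series" means these compounds.

Working notes on the series. All three measured compounds share one core and differ only in the substituent on the aromatic oxygen. In an assay on cells for antagonist activity at transient receptor potential cation channel subfamily V member 1 (Homo sapiens), read by FLIPR and calcium flux, with a stated time of 6 min (a higher number here means a weaker inhibitor, a lower number a stronger inhibitor), compound 1 `CC(C)COc1nc(C(C)(C)C)ccc1CNC(=O)C(C)c1ccc(NS(C)(=O)=O)c(F)c1` gives 0.6 nM. Compound 2 `CC(C(=O)NCc1ccc(C(C)(C)C)nc1OC1CCCCC1)c1ccc(NS(C)(=O)=O)c(F)c1` gives 2.5 nM in this assay, and compound 3 `CC(C(=O)NCc1ccc(C(C)(C)C)nc1OCc1ccccc1)c1ccc(NS(C)(=O)=O)c(F)c1` gives 4.4 nM. Compound 3 therefore holds the highest number of the three, but its gap to compound 2 is small, a 1.8-fold higher number from compound 2 to compound 3 (0.25 log units; within the scatter), whereas the gap to compound 1 is larger, a 7.3-fold higher number from compound 1 to compound 3 (0.87 log units; beyond the scatter). The remaining step, a 4.2-fold higher number from compound 1 to compound 2 (0.62 log units; beyond the scatter), is of similar size.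

Compound 4 `CC(C(=O)NCc1ccc(C(C)(C)C)nc1SCCCN1CCCC1)c1ccc(NS(C)(=O)=O)c(F)c1` is the next member, with a change at the same position: (3-(pyrrolidin-1-yl)propyl)sulfanyl in place of benzyloxy on an aromatic carbon. Within the data shown here, none of the measured steps covers this change; all three concern only what hangs from an aromatic oxygen, and each moves the number by a modest amount, with the largest being a 7.3-fold higher number from compound 1 to compound 3 (0.87 log units; beyond the scatter). Among the measured compounds shown here, with no step that bears directly on the sulfur link or the pyrrolidine chain, the expectation is a step of modest size and uncertain direction, so for compound 4 the estimated step is a 1.8-fold higher number from compound 3 to compound 4 (0.26 log units; within the scatter) in this assay. The expected value for compound 4 is 8 nM, with a range from 2 nM to 40 nM.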

Compound 4, inhibition constant: 17.1 nM
Estimate against measurement, compound 4: 2.1-fold (0.33 log units) below; the range from low to high includes it.
By their numbers in this assay, from the lowest: compound 1; then compounds 2 and 3 (each within the scatter of the next); then compound 4.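

In this assay, the position next to the ring nitrogen still gives a measurable inhibitor when the oxygen link and the group beyond it are both replaced, but compound 4, with (3-(pyrrolidin-1-yl)propyl)sulfanyl, stands apart from all three oxygen-linked compounds: a 3.9-fold higher number from compound 3 to compound 4 (0.59 log units; beyond the scatter), a 6.8-fold higher number from compound 2 to compound 4 (0.84 log units; beyond the scatter) and a 29-fold higher number from compound 1 to compound 4 (1.45 log units; beyond the scatter). Among these compounds, the last of these is the first large step, and all three run in the same direction, so this replacement gives a higher number than any of the isobutoxy, cyclohexyloxy or benzyloxy groups. The data offer nothing that accounts for the size of these steps.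

The sulfur link and the pyrrolidine-bearing chain enter together, so the compounds shown leave open how much of each step belongs to either one. An isobutylsulfanyl group and a 3-(pyrrolidin-1-yl)propoxy group at this position would separate the two, and a shorter chain or an open-chain dimethylamino group in place of the pyrrolidine would show how far the number follows the chain and its terminal amine.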